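From an ethylphenyl to an iodo-methoxyphenyl group

A few compounds are considered here, and "the series" means these few. Any claim that something is new, unique, unknown or untested is made for them only; others in the source may bear on it.

Measured compounds:
compound 1, `COc1cc(NC(=O)Nc2cc(Nc3cc(F)ccc3OC)ncn2)cc(OC)c1`, in a functional assay on HCC827 cells (Homo sapiens) for inhibition, read by MTT assay, with a stated time of 48 h, tested at 10 uM (on this read-out higher numbers stand for more inhibition at the one concentration tested (going by the name of the read-out) and lower numbers for less inhibition), compound 1 gives 59%
compound 2, `CCc1cccc(Nc2cc(NC(=O)Nc3cc(OC)cc(OC)c3)ncn2)c1`, in this assay compound 2 gives 52.6%

On these two numbers compound 2 stands lowest, its nearest neighbour being compound 1, yet the two lie within the scatter of each other, so no order between them is claimed. Among the compounds with values here, the single step that joins them, a number 6.4 percentage points lower from compound 1 to compound 2 (within the scatter), is the only measured step available.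

Compound 3, `COc1cc(NC(=O)Nc2cc(Nc3cc(I)ccc3OC)ncn2)cc(OC)c1`, is not yet measured. It differs from compound 2 by 5-iodo-2-methoxyphenyl in place of 3-ethylphenyl on a nitrogen on an aromatic ring. The entering group differs from the 5-fluoro-2-methoxyphenyl of compound 1 only in the halogen, so the change from compound 2 to compound 3 largely retraces the measured step in the other direction. Since that step stayed within the scatter, the expected step of a number 5.4 percentage points higher from compound 2 to compound 3 (within the scatter) is likewise small, pointing at most slightly upward toward the level of compound 1. Compound 3 is therefore estimated at 58% in this assay, with a range from 42% to 74%.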

Compound 3, a percentage reported as inhibition, at one concentration (the size of the read-out at that concentration, not a potency): 71%
Beside the measured number, compound 3's estimate is 13 percentage points below it, within the range that was stated.
By their numbers in this assay, from the lowest: compounds 2 and 1 (each within the scatter of the next); then compound 3.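

In this assay, within the data shown here, the group on this nitrogen had so far produced no step beyond the scatter, and 5-iodo-2-methoxyphenyl in place of 3-ethylphenyl gives the first, a number 18.4 percentage points higher from compound 2 to compound 3 (beyond the scatter). The halogen alone also moves the number: with the rest of the molecule unchanged, iodo in place of fluoro on an aromatic carbon gives a number 12 percentage points higher from compound 1 to compound 3 (beyond the scatter), so this group is sensitive to a single-atom change that the earlier pair could not reveal. No supporting measurement is available to explain why the iodo compound stands higher.

The compounds shown leave open whether chloro or bromo on that aromatic carbon would reach the level of compound 3 or stay at that of compound 1, and whether a nitrile or a trifluoromethyl there would behave like either halogen. They also leave open what the methoxy contributes alongside the iodo, as no phenyl group carrying the iodo without the methoxy appears among them.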